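The compounds below may be only part of what the source reports. "The series", "measured", "known", "first", "only" and "open" are said of these compounds alone.

Of the compounds shown here, three built on an amide-linked phenol have been tested in a functional assay on MDBK cells (Bos taurus) for cytotoxicity; on this read-out lower numbers stand for higher toxicity in this test and higher numbers for lower toxicity in this test. Compound 1, `Cc1ccc(O)c(C(=O)NCCCCN2CCC[C@@H]3CCCC[C@@H]32)c1`, gives 30 ug/mL. Compound 2, `Cc1ccc(O)c(C(=O)NCCCCN2C(C)CC[C@@H]3CCCC[C@@H]32)c1`, differs from compound 1 by methyl in place of hydrogen on a saturated ring carbon. In this assay compound 2 gives 90 ug/mL; that single change made a 3.0-fold higher number from compound 1 to compound 2 (0.48 log units; beyond the scatter). Compound 3, `Cc1ccc(O)c(C(=O)NCCCN2CCC[C@@H]3CCCC[C@H]32)c1`, carries a different core from compound 1, and the difference between the two cores is not broken down here. In this assay compound 3 gives 60 ug/mL. Set against compound 2, the value of compound 3 lies within the scatter, and set against compound 1 it also lies within the scatter, so no order can be read among these three beyond the one step already named.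

Compound 4, `Cc1ccc(O)c(C(=O)NCCCN2[C@@H]3CCCC[C@H]3CC[C@@H]2C)c1`, has not yet been measured. It differs from compound 3 by methyl in place of hydrogen on a saturated ring carbon. This is the same change as the one that turned compound 1 into compound 2, now made on the core of compound 3; among the compounds shown it occurs twice in all.

Going by the values given here, the only guide to what this change does is that one earlier step. The expected step is a 3.0-fold higher number from compound 3 to compound 4 (0.48 log units; beyond the scatter), because the same change made a 3.0-fold higher number from compound 1 to compound 2 (0.48 log units; beyond the scatter). On that basis compound 4 is estimated to give 180 ug/mL in this assay. The lower end of the estimate for compound 4 is 90 ug/mL. The upper end of the estimate for compound 4 is 360 ug/mL. A single precedent on a different core is a thin basis, so the range is kept wide.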

Compound 4, half-maximal cytotoxic concentration: 30 ug/mL
Beside the measured number, compound 4's estimate is 6.0-fold (0.78 log units) above it; the measured number lies below the stated range.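

In this assay, putting methyl in place of hydrogen on a saturated ring carbon gave a 2.0-fold lower number from compound 3 to compound 4 (0.30 log units; within the scatter), a step too small to be told from repeat-measurement noise, while on the core of compound 1 the same change gave a 3.0-fold higher number from compound 1 to compound 2 (0.48 log units; beyond the scatter). The effect seen on one core therefore did not carry over at the same size to the other, and the gap between the two steps is real: the same change on two cores in this assay, a 3.0-fold higher number (0.48 log units; beyond the scatter) from compound 1 to compound 2 and a 2.0-fold lower number (0.30 log units; within the scatter) from compound 3 to compound 4, 6.0-fold (0.78 log units) apart, beyond the scatter of two such steps

This does not show why the two cores respond differently, since the difference between them is not broken down, and it does not show that methyl truly lowers the number on the core of compound 3. Two pairs also give no rule for what the change would do on a third core.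

The compounds shown leave open what ethyl or hydroxyl would do in place of methyl on the same ring carbon next to the ring nitrogen, on either core. They also leave open whether each core would respond to such a group in its own way, as it did to methyl.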